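Swapping the Chloropyridine Amide for a Plain Pyridine

A few compounds are considered here, and "the series" means these few. Any claim that something is new, unique, unknown or untested is made for them only; others in the source may bear on it.

Within the data shown here, compound 3 `O=C(Nc1nnc(-c2ccc3c(c2)OCCO3)s1)c1ccc(Cl)nc1` gives 30.4 ug/mL in a functional assay on SW 1116 cells (Homo sapiens) for antiproliferative activity, read by MTT assay, with a stated time of 48 h (a higher number here means that more compound is needed for the effect, a lower number that less compound is needed), the second highest of the three numbers measured so far. Its nearest neighbour is compound 2 `O=C(CCc1ccccc1)Nc1nnc(-c2ccc3c(c2)OCCO3)s1`, which gives 16.2 ug/mL; the step of a 1.9-fold higher number from compound 2 to compound 3 (0.27 log units; within the scatter) lies within the scatter. Compound 1 `O=C(Nc1nnc(-c2ccc3c(c2)OCCO3)s1)c1ccccc1` gives 67.6 ug/mL, and the step of a 2.2-fold lower number from compound 1 to compound 3 (0.35 log units; beyond the scatter) is modest. Compound 4 `O=C(Nc1nnc(-c2ccc3c(c2)OCCO3)s1)c1ccncc1` differs from compound 3 only at the amide: pyridin-4-yl in place of 6-chloropyridin-3-yl on a carbonyl carbon. Among the measured compounds shown here, no measured step exchanges one pyridine for another; the only step that bears on the change is a 2.2-fold lower number from compound 1 to compound 3 (0.35 log units; beyond the scatter), and compound 4 keeps the pyridine but not the chlorine. Compound 4 is therefore expected to move by a small step, a 1.5-fold higher number from compound 3 to compound 4 (0.17 log units; within the scatter), toward a higher number. The estimate for compound 4 is 45 ug/mL, with a range from 22 ug/mL to 95 ug/mL.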

Compound 4, half-maximal effective concentration: > 100 ug/mL
Compound 4: a limit, no number (the forecaster's own chance of this, stated with the estimate: 5%); at least 2.2-fold (0.34 log units) between middle value and limit.
By their numbers in this assay, from the lowest: compounds 2 and 3 (each within the scatter of the next); then compound 1. At a limit, above all of these: compound 4.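

In this assay compound 4 stands at a limit, not a number: the limit of > 100 ug/mL in this assay, at which 1 of the 4 values shown sits. The change on the carbonyl carbon is therefore not neutral, giving an at least 3.2-fold higher number from compound 3 to compound 4 (0.51 log units; beyond the scatter) and, against the phenethyl amide, an at least 6.1-fold higher number from compound 2 to compound 4 (0.79 log units; beyond the scatter), so a pyridine ring alone did not keep the lower number of compound 3. Against the phenyl amide the result, an at least 1.4-fold higher number from compound 1 to compound 4 (0.17 log units; that floor lies within the scatter), separates nothing. The compounds shown leave open whether the chlorine or the point of attachment of the ring accounts for the step. A plain pyridin-3-yl or a 6-aminopyridin-3-yl amide would bear on that question.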